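The compounds below may be only part of what the source reports. "The series", "measured", "known", "first", "only" and "open" are said of these compounds alone.

Measured so far in an assay on CHO-K1 cells for antagonist activity at adenosine receptor A1 (Homo sapiens), read by a beta-galactosidase reporter, with stated times of 15 min and 6 h; a higher number here means a weaker inhibitor, a lower number a stronger inhibitor: compound 1 `Nc1nc(-c2ccco2)nc2sc(CNC3CCCCC3)cc12` gives 2480 nM; compound 2 `Nc1nc(-c2ccco2)nc2sc(CN3CC=CCC3)cc12` gives 150 nM; compound 3 `Nc1nc(-c2ccco2)nc2sc(CN3CCC(F)(F)CC3)cc12` gives 2230 nM.

Compound 3 sits close to compound 1, the step between them being a 1.1-fold lower number from compound 1 to compound 3 (0.05 log units; within the scatter), while it lies far from compound 2, as shown by a 15-fold higher number from compound 2 to compound 3 (1.17 log units; beyond the scatter). Compound 4 `Nc1nc(-c2ccco2)nc2sc(CN3CCC(O)CC3)cc12` differs from compound 3 by 4-hydroxypiperidin-1-yl in place of 4,4-difluoropiperidin-1-yl on a saturated chain carbon bound to an aromatic carbon. Among the measured compounds shown here, no measured step replaces 4,4-difluoropiperidin-1-yl with 4-hydroxypiperidin-1-yl. The two steps altering the same ring were a 17-fold lower number from compound 1 to compound 2 (1.22 log units; beyond the scatter) and a 15-fold higher number from compound 2 to compound 3 (1.17 log units; beyond the scatter), both large, whereas a 1.1-fold lower number from compound 1 to compound 3 (0.05 log units; within the scatter) was small. With the saturated ring kept, the expected step of a 1.9-fold lower number from compound 3 to compound 4 (0.27 log units; within the scatter) is modest and of uncertain direction. Compound 4 is therefore estimated at 1200 nM, within 300 nM to 5000 nM.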

Compound 4, inhibition constant: 4000 nM
For compound 4 the middle estimate is 3.3-fold (0.52 log units) below the measured one, within the range that was stated.
By their numbers in this assay, from the lowest: compound 2; then compounds 3, 1 and 4 (each within the scatter of the next).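

In this assay, 4-hydroxypiperidin-1-yl on a saturated chain carbon bound to an aromatic carbon cannot be told apart from 4,4-difluoropiperidin-1-yl (a 1.8-fold higher number from compound 3 to compound 4 (0.25 log units; within the scatter)) or from cyclohexylamino (a 1.6-fold higher number from compound 1 to compound 4 (0.21 log units; within the scatter)), so the added hydrogen-bond donor brings no separation. Compound 2 alone stands apart, now from all three other compounds, including compound 4 (a 27-fold higher number from compound 2 to compound 4 (1.43 log units; beyond the scatter)). Nothing available explains these results. Going by these compounds, it remains open whether plain piperidin-1-yl would sit with compound 2 or with the other three compounds. The same holds for morpholin-4-yl and 4-aminopiperidin-1-yl on that carbon.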